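Chain Length and Amine Change on One Shared Core

The compounds below may be only part of what the source reports. "The series", "measured", "known", "first", "only" and "open" are said of these compounds alone.

Compound 1 `CCCCCCC(CCO)n1cnc2c(N(C)C)ncnc21`: > 50000 nM
Compound 2 `CCCCCCC(CCO)n1cnc2c(N)ncnc21`: > 50000 nM
Compound 3 `CCCCCCCCCC(CCO)n1cnc2c(N(C)C)ncnc21`: 9810 nM

Within the data shown here, in a functional assay on HCT-116 cells (Homo sapiens) for antiproliferative activity, read by MTT assay, with a stated time of 48 h (on this read-out lower numbers stand for stronger inhibition and higher numbers for weaker inhibition), compound 3 gives 9810 nM, the only number in the set. Compound 1 gives only a limit, > 50000 nM. Compound 2 likewise reaches only a limit, > 50000 nM. The change from compound 1 to compound 3, (propyl in place of hydrogen on a saturated chain carbon, seven bonds along the chain from an aromatic nitrogen), gives an at least 5.0-fold lower number from compound 1 to compound 3 (0.70 log units; beyond the scatter). The change from compound 1 to compound 2, (amino in place of dimethylamino on an aromatic carbon), gives a step that the two limits leave unreadable from compound 1 to compound 2, because the limit of > 50000 nM in this assay, at which 2 of the 3 values shown sit, hides whatever the step was.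

Compound 4 `CCCCCCCCCC(CCO)n1cnc2c(N)ncnc21` is not yet measured. It differs from compound 3 by amino in place of dimethylamino on an aromatic carbon, the same change that turns compound 1 into compound 2. Since that earlier step left no readable size, the expectation for compound 4 rests only on compound 3 and its value 9810 nM. The step of a 1.5-fold higher number from compound 3 to compound 4 (0.18 log units; within the scatter) is expected to be modest. Compound 4 is therefore estimated at 15000 nM, between 5000 nM and 45000 nM.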

Compound 4, half-maximal inhibitory concentration: 10500 nM
Compound 4: the middle estimate sits 1.4-fold (0.15 log units) above what was measured; the range from low to high includes it.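

In this assay, propyl in place of hydrogen on the amino core gives an at least 4.7-fold lower number from compound 2 to compound 4 (0.67 log units; beyond the scatter), while amino in place of dimethylamino on the longer chain gives a 1.1-fold higher number from compound 3 to compound 4 (0.03 log units; within the scatter). The chain change therefore lowers the number in the same direction on both cores, so in these four compounds it carries over from the dimethylamino core to the amino core: the same change on two cores in this assay, an at least 5.0-fold lower number (0.70 log units; beyond the scatter) from compound 1 to compound 3 and an at least 4.7-fold lower number (0.67 log units; beyond the scatter) from compound 2 to compound 4; the limit leaves it open whether they differ. This does not show that the chain change has the same size on both cores, and the amine change has only one readable step, since the steps that start from or end at two limits cannot be read, because compound 1 and compound 2 both stand at a limit: the limit of > 50000 nM in this assay, at which 2 of the 4 values shown sit.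

The compounds shown leave open how a chain longer than that of compound 3 would read, and whether the amine change would stay as small with a larger amine such as diethylamino. They also leave open what a carboxylic acid at the chain end would do on the shared core.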